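Methoxy for iodo: an expected loss of growth inhibition

A few compounds are considered here, and "the series" means these few. Any claim that something is new, unique, unknown or untested is made for them only; others in the source may bear on it.

Measured in a functional assay on A549 cells (Homo sapiens) for inhibition; a lower number here means a stronger inhibitor of growth, a higher number a weaker inhibitor of growth:
compound 1 `NC(=O)c1cc(Cl)ccc1NC(=O)COc1ccccc1`: 7060 nM
compound 2 `NC(=O)c1cc(I)ccc1NC(=O)COc1ccccc1`: 732 nM

Compound 2 holds the lower of the two numbers, at 732 nM. The next case is compound 3 `COc1ccc(NC(=O)COc2ccccc2)c(C(N)=O)c1`, with methoxy in place of iodo on an aromatic carbon, para to a large group: methoxy in place of iodo on an aromatic carbon. Among the measured compounds shown here, one measured step bears on this change: a 9.6-fold lower number from compound 1 to compound 2 (0.98 log units; beyond the scatter), a modest step beyond the scatter, with iodo in place of chloro. For the measured compounds named here, no methoxy compound has been measured, so that step gives only a rough size. Compound 1, which lacks the iodo group, gives 7060 nM, and a step of similar size towards a higher number is therefore expected in this assay. The expected step is a 6.8-fold higher number from compound 2 to compound 3 (0.83 log units; beyond the scatter). For compound 3 the estimate is 5000 nM, with an expected range of 1500 nM to 20000 nM.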

Compound 3, concentration for 50% growth inhibition: 908 nM
Compound 3: the middle estimate sits 5.5-fold (0.74 log units) above what was measured; the whole stated range lies above it.
By their numbers in this assay, from the lowest: compounds 2 and 3 (each within the scatter of the next); then compound 1.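

In this assay, methoxy in place of iodo gives a 1.2-fold higher number from compound 2 to compound 3 (0.09 log units; within the scatter), so this position accepts two different groups with no separable difference in growth inhibition. The advantage over chloro is therefore not unique to iodo: methoxy in place of chloro gives a 7.8-fold lower number from compound 1 to compound 3 (0.89 log units; beyond the scatter), in the same direction as a 9.6-fold lower number from compound 1 to compound 2 (0.98 log units; beyond the scatter), and compound 1 alone stands apart among the three. Nothing on hand speaks to what lies behind this result.

Open, from the compounds shown here alone, is whether bromo, ethoxy or an amine at this position would match compound 2 and compound 3 or fall towards compound 1. Also open, going by these compounds, is whether a carboxylic acid or a longer alkoxy chain would be accepted here.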